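Compound 4 and a Cytotoxicity Limit

The source may report more compounds than this note shows. Statements on the series, on what has been measured and on what is new or still open speak of the compounds shown alone.

Measured in an ADME assay on HCT-116 cells (Homo sapiens) for cytotoxicity, read by CellTiter-Glo, with a stated time of 72 h; on this read-out lower numbers stand for stronger inhibition and higher numbers for weaker inhibition:
- Compound 1 `CC1CCN(C2CCN(S(=O)(=O)c3ccc(-c4ccccc4F)cc3)CC2)CC1`: > 5000 nM
- Compound 2 `COc1ccc(NC(=O)N2CCC(N3CCC(C)CC3)CC2)cc1`: > 5000 nM
- Compound 3 `Cc1cc(C)c(S(=O)(=O)N2CCC(N3CCC(CCC#N)CC3)CC2)c(C)c1`: > 5000 nM

None of these three entries is a number, for each is a limit of the assay. Compound 1 stands at the limit of > 5000 nM in this assay, at which 3 of the 3 values shown sit. Within the data shown here, the measured compounds therefore offer no step whose size could be read, and they give no ranking.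

Compound 4 `CC1CCN(C2CCN(S(=O)(=O)c3ccc(OCc4ccccc4)cc3)CC2)CC1` keeps the core of compound 1 and differs in one place, on an aromatic carbon, para to a large group: benzyloxy in place of 2-fluorophenyl (benzyloxy in place of 2-fluorophenyl on an aromatic carbon). Among the measured compounds shown here, no measured pair shows what such a change does.

The expectation rests on compound 1, whose > 5000 nM is a limit. In this assay, no step beyond the scatter is expected in either direction, and compound 4 will most likely be reported at the limit as well. The estimated change is a step that the limit leaves unreadable from compound 1 to compound 4. For compound 4, the estimated half-maximal inhibitory concentration is 7000 nM, with an expected range of 3000 nM to 15000 nM.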

Compound 4, half-maximal inhibitory concentration: > 5000 nM
Compound 4 was reported as a limit; the forecaster's own chance of this, stated with the estimate: 85%; the middle value lies beyond the limit too.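

In this assay, among these compounds, compound 1 and compound 4 both stand at a limit of the assay and not at a number, so no step between them can be read: the limit of > 5000 nM in this assay, at which 4 of the 4 values shown sit. The compounds shown leave open whether benzyloxy in place of 2-fluorophenyl changes cytotoxicity at all, and how these compounds rank against one another.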